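Chloro added to the benzyl group of compound 2

This account rests on a few compounds, and the source may have more. Where it says the series, first, only, none or still open, it means among the compounds named here.

Among the compounds with values here, compound 2 `CC1=C(C(=O)Nc2ccc(F)cc2)C(c2ccc([N+](=O)[O-])cc2)N=C(SCc2ccccc2)N1` is one of two compounds measured in a functional assay on the whole organism (artery, strain albino) with Rattus norvegicus as the target, with a stated time of 15 min, at a dose of 10 mg/kg by the oral route; on this read-out lower numbers stand for less inhibition and higher numbers for more inhibition at the one dose given (going by the name of the read-out). Compound 2 gives 3.1%, and compound 1 `COc1ccc(C2N=C(SCc3ccccc3)NC(C)=C2C(=O)Nc2ccc(F)cc2)cc1OC` gives 1.5%; the step of a number 1.6 percentage points higher from compound 1 to compound 2 (within the scatter) changes only the aryl group on the saturated ring carbon. Compound 3 `CC1=C(C(=O)Nc2ccc(F)cc2)C(c2ccc([N+](=O)[O-])cc2)N=C(SCc2cccc(Cl)c2)N1` differs from compound 2 by chloro in place of hydrogen on an aromatic carbon. No measured step touches the benzylsulfanyl group, so nothing shown bears on this change, and a step no larger than the scatter is expected, a number 0.1 percentage points lower from compound 2 to compound 3 (within the scatter). Compound 3 is therefore estimated at 3%, with a range from -5% to 12%.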

Compound 3, a percentage reported as inhibition, in the whole organism at one dose (the size of the read-out at that dose, not a potency): 2.1%
Compound 3: the middle estimate sits 0.9 percentage points above what was measured, and the stated range covers the measured number.
By their numbers in this assay, from the lowest: compounds 1, 3 and 2 (each within the scatter of the next).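

Within the data shown here, this is the first measured step on the benzylsulfanyl group: in this assay, (3-chlorobenzyl)sulfanyl in place of benzylsulfanyl gives a number 1 percentage points lower from compound 2 to compound 3 (within the scatter) and so adds a first reading at this part of the molecule. For this one pair, chloro on the aromatic carbon meta to a large group leaves the read-out within the scatter. No measurement bearing on this result is available to interpret it.

Still open, going by these compounds, is whether an amine or a carboxylic acid on this ring would give a step beyond the scatter. A longer chain in place of benzyl is equally untested by the compounds shown.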